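Shortening the nitrile chain on a tetrabrominated benzimidazole core

A few compounds are considered here, and "the series" means these few. Any claim that something is new, unique, unknown or untested is made for them only; others in the source may bear on it.

Measured so far:
compound 1 `N#CCCn1cnc2c(Br)c(Br)c(Br)c(Br)c21` gives 44%
compound 2 `Cc1nc2c(Br)c(Br)c(Br)c(Br)c2n1CCCC#N` gives 44%
compound 3 `N#CCCCCn1cnc2c(Br)c(Br)c(Br)c(Br)c21` gives 70%

In a functional assay on CCRF-CEM cells (Homo sapiens) for cytotoxicity, read by MTT assay, with a stated time of 24 h, tested at 20 uM (a lower number here means a stronger effect, a higher number a weaker effect of the compound at the concentration tested), compound 3 holds the highest of the three numbers; compound 1 and compound 2 both sit lower, and each of those gaps lies beyond the scatter. Compound 4 `N#CCCCn1cnc2c(Br)c(Br)c(Br)c(Br)c21` differs from compound 3 by cyano in place of cyanomethyl on a saturated chain carbon, three bonds along the chain from an aromatic nitrogen; read one bond further out, the 4-cyanobutyl chain shortens to 3-cyanopropyl. Among the compounds with values here, the one step that bears on this is a number 26 percentage points higher from compound 1 to compound 3 (beyond the scatter), where lengthening the chain from 2-cyanoethyl to 4-cyanobutyl raised the number. Compound 4 sits between those two chain lengths, so a downward step from compound 3 is expected, of about a number 13 percentage points lower from compound 3 to compound 4 (beyond the scatter). Compound 4 is therefore estimated at 57%, in the range 42% to 72%.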

Compound 4, a percentage reported as activity, at one concentration (the size of the read-out at that concentration, not a potency): 70%
Beside the measured number, compound 4's estimate is 13 percentage points below it; low and high end bracket the measured number.
By their numbers in this assay, from the lowest: compounds 1 and 2 (each within the scatter of the next); then compounds 3 and 4 (each within the scatter of the next).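

In this assay shortening the 4-cyanobutyl chain to 3-cyanopropyl leaves the number in place, with no change at the digits printed from compound 3 to compound 4 (within the scatter) here, so among these chains the rise is already complete at 3-cyanopropyl, with a number 26 percentage points higher from compound 1 to compound 4 (beyond the scatter) on going up from 2-cyanoethyl. With the 3-cyanopropyl chain kept, the methyl on the aromatic carbon also counts, with a number 26 percentage points higher from compound 2 to compound 4 (beyond the scatter) on replacing it by hydrogen. No evidence at hand explains either shift. Still open, going by these compounds, is whether a longer chain, or an amine or carboxylic acid in place of the nitrile, would hold the number in this range.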